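The compounds below may be only part of what the source reports. "The series", "measured", "known", "first", "only" and "open" are said of these compounds alone.

Measured in an ADME assay on Vero cells (Chlorocebus sabaeus) for cytotoxicity, read by MTT assay, with a stated time of 72 h; a lower number here means that less compound is tolerated, a higher number that more compound is tolerated:
- compound 1 `COc1ccc(-c2cc(-c3ccc(C4NC(=O)c5ccccc5N4)cc3)nc(N)n2)cc1`: 124000 nM
- compound 2 `CC1(c2ccc(Nc3nc(Nc4ccccc4)nc(Nc4ccccc4)n3)cc2)NC(=O)c2ccccc2N1`: "not determined" (no result reported)
- compound 3 `CCCCNc1nc(NCCCC)nc(Nc2ccc(C3(C)NC(=O)c4ccccc4N3)cc2)n1`: 142000 nM

For the measured compounds named here, only two compounds have numbers here. Going by the values given here, compound 1 at 124000 nM and compound 3 at 142000 nM lie within the usual scatter of each other, so compound 1 stands level with the only other measured compound. Compound 4 `Nc1nc(-c2ccc(Br)cc2)cc(-c2ccc(C3NC(=O)c4ccccc4N3)cc2)n1` has not yet been measured. It keeps the core of compound 1 and changes in one place, with bromo in place of methoxy on an aromatic carbon, para to a large group: bromo in place of methoxy on an aromatic carbon.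

Among the compounds with values here, no two measured compounds differ in just one place, so no measured step shows what such a change does in this assay. Within the data shown here, the only guide is that the two numbers are level although the structures of compound 1 and compound 3 differ widely. A step beyond the scatter, in either direction, is therefore not expected. The expected change is a 1.1-fold lower number from compound 1 to compound 4 (0.05 log units; within the scatter). For compound 4 the estimated value is 110000 nM, with an expected range from 50000 nM to 220000 nM.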

Compound 4, half-maximal cytotoxic concentration: > 400000 nM
Compound 4: no number, only a limit; the forecaster's own chance of this, stated with the estimate: 15%; at least 3.6-fold (0.56 log units) between middle value and limit.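

For the compounds shown here, the compounds measured earlier offered no pair differing in one place, so this is the first direct reading of such a change. In this assay, going from 4-methoxyphenyl to 4-bromophenyl, on an aromatic carbon para to a large group, gives an at least 3.2-fold higher number from compound 1 to compound 4 (0.50 log units; beyond the scatter), so more compound is tolerated with bromo at this position. The full size of this step cannot be read, because compound 4 rests on a limit and not a number: the limit of > 400000 nM in this assay, at which 1 of the 4 values shown sits.

From the compounds shown here alone, whether the rise belongs to bromo itself or to the loss of methoxy stays open, and a chloro group, an amine or a plain hydrogen at this position would speak to that. A single pair also leaves open whether the same change would act alike on a different core.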